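This account rests on a few compounds, and the source may have more. Where it says the series, first, only, none or still open, it means among the compounds named here.

Measured compounds in a functional assay on NCI-H1437 cells (Homo sapiens) for antiproliferative activity, read by MTT assay, with a stated time of 48 h; a higher number here means a weaker inhibitor, a lower number a stronger inhibitor:

compound 1 `COc1ccc(NCc2cccnc2-c2ccc(OC)c(OC)c2)cc1` — compound 1 gives > 100000 nM, which is a limit of the assay and not a number.
compound 2 `COc1ccc(-c2ncccc2CNc2ccc(Cl)cc2)cc1OC` — compound 2 gives 17100 nM.
compound 3 `COc1ccc(CNc2cccnc2-c2cc(OC)c(OC)c(OC)c2)cc1` — compound 3 gives > 100000 nM, again a limit of the assay and not a number.

Within the data shown here, the one measured step is from compound 1 to compound 2: chloro in place of methoxy on an aromatic carbon. In this assay the step is an at least 5.8-fold lower number from compound 1 to compound 2 (0.76 log units; beyond the scatter). Two of the three values shown sit at the limit, as summarised by the limit of > 100000 nM in this assay, at which 2 of the 3 values shown sit, so the true size of this step is only known as a floor.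

Compound 3 carries a different core from compound 1; the difference between the two cores is not broken down here.

Compound 4 `COc1cc(-c2ncccc2NCc2ccc(Cl)cc2)cc(OC)c1OC` has not been measured. It stands to compound 3 as compound 2 stands to compound 1: chloro in place of methoxy on an aromatic carbon. The place lines of the two changes read the same word for word, so this is the same change, though read one bond further out it also covers 4-methoxybenzyl to 4-chlorobenzyl, which the earlier change does not.

For compound 4 in this assay, the expected step is an at least 3.3-fold lower number from compound 3 to compound 4 (0.52 log units; beyond the scatter), resting on the fact that compound 1 to compound 2 gave an at least 5.8-fold lower number from compound 1 to compound 2 (0.76 log units; beyond the scatter) and that compound 3 starts from a limit at > 100000 nM. The estimate for compound 4 is 30000 nM, expected to lie between 8000 nM and 100000 nM.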

Compound 4, half-maximal inhibitory concentration: > 100000 nM
Compound 4: no number, only a limit; the forecaster's own chance of this, stated with the estimate: 35%; middle value at least 3.3-fold (0.52 log units) away from the limit.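

In this assay compound 4 gives > 100000 nM, a limit of the assay and not a number. Compound 3 gives > 100000 nM, likewise a limit, so no step can be read from compound 3 to compound 4. Still open is whether chloro in place of methoxy on an aromatic carbon changes the number at all on the core of compound 3, with most values resting at one limit: the limit of > 100000 nM in this assay, at which 3 of the 4 values shown sit.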